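Swapping Methoxy for Chloro in a Sulfonamide Series

The compounds below may be only part of what the source reports. "The series", "measured", "known", "first", "only" and "open" are said of these compounds alone.

Four compounds share one core. Compound 1 `NC(=O)c1cc(NS(=O)(=O)c2ccc(F)cc2)cc(-c2ccc3nc(NC(=O)C4CC4)sc3c2)c1` has no result in a functional assay on MCF7 cells (Homo sapiens) for antiproliferative activity, read by MTT assay, with a stated time of 72 h; a lower number here means a stronger inhibitor, a higher number a weaker inhibitor: for compound 1 the entry reads "not determined" (no result reported). Compound 2 `COc1c(NS(=O)(=O)c2ccc(F)cc2)cc(-c2ccc3nc(NC4CC4)sc3c2)cc1C(N)=O` stands the same way: for compound 2 the entry in this assay reads "not determined" (no result reported). Going by the values given here, compound 3 `COc1c(NS(=O)(=O)c2ccc(F)cc2)cc(-c2ccc3nc(NC(=O)C4CC4)sc3c2)cc1C(N)=O` is the one member with a measurement: in this assay compound 3 gives 1580 nM. Since that is the only number shown, compound 3 cannot be ranked against any other member of the set in this assay; it simply marks the starting point.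

Compound 4 `NC(=O)c1cc(-c2ccc3nc(NC(=O)C4CC4)sc3c2)cc(NS(=O)(=O)c2ccc(F)cc2)c1Cl` differs from compound 3 in a single place: chloro in place of methoxy on an aromatic carbon. Among the compounds with values here, no pair of measured compounds shows what such a swap does in this assay, so there is no measured step to lean on. Within the data shown here, with only one number available, the most defensible expectation is a change no larger than the usual scatter and of no clear direction. The expected step is a 1.2-fold lower number from compound 3 to compound 4 (0.08 log units; within the scatter). For compound 4 the estimated value in this assay is 1300 nM, with a range from 400 nM to 4500 nM.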

Compound 4, half-maximal inhibitory concentration: > 50000 nM
Compound 4: only a limit was reported; the forecaster's own chance of this, stated with the estimate: 5%; middle value at least 38-fold (1.58 log units) from the limit.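

In this assay, the place on the aromatic carbon ortho to a ((4-fluorophenyl)sulfonyl)amino group and ortho to a carbamoyl group proves sensitive to what sits on it: chloro in place of methoxy gives an at least 31-fold higher number from compound 3 to compound 4 (1.50 log units; beyond the scatter). Compound 4 is reported only as a limit, not as a number: the limit of > 50000 nM in this assay, at which 1 of the 4 values shown sits. On these data alone, the true size of the step therefore stays open on the upper side, but this one pair shows that a single exchange at this place can separate a compound with a measured value from one that reaches the limit.

Compound 1, with no substituent at this place, has no result, so the pair alone cannot tell whether methoxy helps or chloro harms. As far as these compounds go, how an amine, a hydroxyl or a longer ethoxy chain would read here also remains open.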